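The source may hold more compounds than are shown below. What is called first, only, known or untested is meant among the compounds shown, and "the series" means these compounds.

Working notes on the series. Compound 1 is `CCCOC(=O)c1c(C)coc1-c1ccc2c(CC)cccc2c1OC` and compound 2 is `CCc1cccc2c(OC)c(-c3occ(C)c3C(=S)OC)ccc12`; the two share one core and differ at a single group on an aromatic carbon. In a functional assay on SK-BR-3 cells (Homo sapiens) for cytotoxicity, read by MTT assay, with a stated time of 72 h (on this read-out lower numbers stand for an effect already at smaller amounts and higher numbers for an effect only at larger amounts of compound), compound 1 gives only a limit, > 10 ug/mL. In this assay, going by the values given here, compound 2 gives 6.3 ug/mL, the only number in the set so far. Among the compounds with values here, the step of an at least 1.5-fold lower number from compound 1 to compound 2 (0.20 log units; that floor lies within the scatter) rests on that limit, as the limit of > 10 ug/mL in this assay, at which 1 of the 2 values shown sits, states, so its true size is open; compound 2 stands as the one compound with a number, the other value being a limit.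

Compound 3 is `CCc1cccc2c(OC)c(-c3occ(C)c3C(=O)NC)ccc12`. It differs from compound 2 by a group of 4 heavy atoms (2 carbon, 1 nitrogen, 1 oxygen; no ring) in place of a group of 4 heavy atoms (2 carbon, 1 oxygen, 1 sulfur; no ring), on an aromatic carbon. Within the data shown here, no measured step exchanges the group that leaves here for the one that enters, and the only step at the same position, an at least 1.5-fold lower number from compound 1 to compound 2 (0.20 log units; that floor lies within the scatter), may itself lie within the scatter. The expected step is therefore a 1.3-fold higher number from compound 2 to compound 3 (0.10 log units; within the scatter), not beyond the scatter. For compound 3 the estimated value in this assay is 8 ug/mL, with a range from 3 ug/mL to 20 ug/mL.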

Compound 3, concentration for half-maximal effect: > 10 ug/mL
Compound 3 gave a limit, no number; the forecaster's own chance of this, stated with the estimate: 35%; middle value at least 1.2-fold (0.09 log units) away from the limit.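

In this assay compound 3 gives > 10 ug/mL, which is a limit and not a number. Placing methylcarbamoyl, with its 1 hydrogen-bond donor, where the sulfur-bearing group of compound 2 stands, on an aromatic carbon of a five-membered aromatic ring with 1 oxygen, gives an at least 1.5-fold higher number from compound 2 to compound 3 (0.20 log units; that floor lies within the scatter); this change therefore does not keep a measured value in the range, but its floor does not establish a difference beyond the scatter, and its true size remains open. The step between compound 1 and compound 3 cannot be read, and compound 2 remains the only compound with a number at this position: the limit of > 10 ug/mL in this assay, at which 2 of the 3 values shown sit.

The compounds shown leave open how far compound 1 and compound 3 lie from compound 2, and whether either differs from the other. A methyl ester at this position would separate the exchange of sulfur for oxygen from the change of chain between compound 1 and compound 2, while a carboxylic acid or a dimethylamide would extend the comparison in this assay to further groups on the same carbon.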